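A few compounds are considered here, and "the series" means these few. Any claim that something is new, unique, unknown or untested is made for them only; others in the source may bear on it.

Compound 1 `CCCN(CC[C@H]1CC[C@H](NC(=O)/C=C/c2ccc(F)cc2)CC1)[C@H]1CCc2nc(N)sc2C1` gives 1 nM in an assay on brain for displacement of a labelled ligand from D(3) dopamine receptor (Rattus norvegicus); a lower number here means a stronger inhibitor, a higher number a weaker inhibitor.
Compound 2 `CCCN(CC[C@H]1CC[C@H](NC(=O)/C=C/c2ccc(OC)cc2)CC1)[C@H]1CCc2nc(N)sc2C1` gives 6.7 nM.
Compound 3 `CCCN(CC[C@H]1CC[C@H](NC(=O)c2cccc3ncccc23)CC1)[C@H]1CCc2nc(N)sc2C1` gives 1.6 nM.

Among these three, compound 3 stands second: its gap to compound 1 is within the usual scatter (a 1.6-fold higher number from compound 1 to compound 3 (0.20 log units; within the scatter)), while compound 2 lies clearly apart (a 4.2-fold lower number from compound 2 to compound 3 (0.62 log units; beyond the scatter)). Compound 4 `CCCN(CC[C@H]1CC[C@H](NC(=O)c2ccccc2-n2cccn2)CC1)[C@H]1CCc2nc(N)sc2C1` differs from compound 3 at one place only: 2-(1H-pyrazol-1-yl)phenyl in place of quinolin-5-yl on a carbonyl carbon. The measured steps that bear on this are the two that likewise exchange the group on this carbonyl carbon, a 1.6-fold higher number from compound 1 to compound 3 (0.20 log units; within the scatter) and a 4.2-fold lower number from compound 2 to compound 3 (0.62 log units; beyond the scatter); both were modest or within the scatter. A similar exchange is therefore expected to shift this assay only a little, if at all, perhaps slightly toward a higher number. Compound 4 is estimated at 3 nM, within a range of 0.8 nM to 12 nM, an expected step of a 1.9-fold higher number from compound 3 to compound 4 (0.27 log units; within the scatter).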

Compound 4, inhibition constant: 2 nM
Beside the measured number, compound 4's estimate is 1.5-fold (0.18 log units) above it; low and high end bracket the measured number.
By their numbers in this assay, from the lowest: compounds 1, 3 and 4 (each within the scatter of the next); then compound 2.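

In this assay the carbonyl carbon also carries 2-(1H-pyrazol-1-yl)phenyl with little consequence, a group with a five-membered aromatic ring: the steps stay within the scatter (a 1.3-fold higher number from compound 3 to compound 4 (0.10 log units; within the scatter)) and (a 2.0-fold higher number from compound 1 to compound 4 (0.30 log units; within the scatter)). The gap to the methoxy compound remains beyond the scatter (a 3.4-fold lower number from compound 2 to compound 4 (0.53 log units; beyond the scatter)). Nothing measured here gives a reason for these numbers. The compounds shown leave open whether a carbonyl carbon bearing a plain cyclohexyl group, with no aromatic ring, or a group carrying a carboxylic acid would give similar numbers.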